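Amide to ester on the shared core: a step awaiting measurement

This account rests on a few compounds, and the source may have more. Where it says the series, first, only, none or still open, it means among the compounds named here.

Compound 1, `CCN(CC)CCCNC(=O)c1ccc(C(CC)(CC)c2ccc(OCC(O)C(C)(C)C)c(C)c2)n1CC`: in a functional assay on MCF7 cells (Homo sapiens), read by MTT assay, with a stated time of 48 h (on this read-out lower numbers stand for stronger inhibition and higher numbers for weaker inhibition), compound 1 gives 190 nM.
Compound 2, `CC[C@@H](C)[C@H](NC(=O)c1ccc(C(CC)(CC)c2ccc(OCC(=O)C(C)(C)C)c(C)c2)n1CC)C(=O)O`: in this assay compound 2 gives 160 nM.
Compound 3, `CCn1c(C(=O)N(C)CC(=O)O)ccc1C(CC)(CC)c1ccc(OCC(=O)C(C)(C)C)c(C)c1`: in this assay compound 3 gives 28600 nM.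

Among these three numbers compound 1 stands second highest; compound 2 sits within the scatter of it, while compound 3 lies far above both. The unmeasured compound 4, `CCn1c(C(=O)Oc2ccc(CCO)cc2)ccc1C(CC)(CC)c1ccc(OCC(O)C(C)(C)C)c(C)c1`, differs from compound 1 in one place: a group of 10 heavy atoms (8 carbon, 2 oxygen; one six-membered aromatic ring of carbon only) in place of a group of 9 heavy atoms (7 carbon, 2 nitrogen; no ring), on a carbonyl carbon. For the measured compounds named here, only one measured step touches this carbonyl carbon, a 180-fold higher number from compound 2 to compound 3 (2.25 log units; beyond the scatter), and it shows that what hangs on that carbon can move the number a great deal. Going by the values given here, that step, however, exchanges one amino group for another, whereas compound 4 carries an oxygen-linked group there, a kind of change no measured pair covers. The size and direction of the step are therefore uncertain; given how strongly compound 3 departed from compound 2, a higher number is expected for compound 4, with the step of a 6.3-fold higher number from compound 1 to compound 4 (0.80 log units; beyond the scatter) as the estimate. Compound 4 is expected to give 1200 nM, in a range from 200 nM to 10000 nM.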

Compound 4, half-maximal inhibitory concentration: > 50000 nM
Compound 4: a limit, no number (the forecaster's own chance of this, stated with the estimate: 10%); middle value at least 41-fold (1.61 log units) from the limit.
By their numbers in this assay, from the lowest: compounds 2 and 1 (each within the scatter of the next); then compound 3. At a limit, above all of these: compound 4.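

Compound 4 carries the only oxygen-linked group on this carbonyl carbon among the compounds shown, and its result in this assay is a limit and not a number: the limit of > 50000 nM in this assay, at which 1 of the 4 values shown sits. Replacing (3-(diethylamino)propyl)amino with this group, which brings in a six-membered aromatic ring, gives an at least 260-fold higher number from compound 1 to compound 4 (2.42 log units; beyond the scatter). The earlier compounds had shown a large change at this carbon only from one amino group to another, a 180-fold higher number from compound 2 to compound 3 (2.25 log units; beyond the scatter), so the new step extends that sensitivity to a change in the linking atom.

The step changes the linking atom, the ring and the chain together, so the compounds shown cannot tell which of these accounts for it. An ester bearing the 3-(diethylamino)propyl chain, or an amide bearing the same hydroxyethyl-substituted aromatic ring, would be needed to separate them.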